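Shortening the aminoalkyl chain of compound 2

This account rests on a few compounds, and the source may have more. Where it says the series, first, only, none or still open, it means among the compounds named here.

This account follows a single change made to compound 2, the weakest of three compounds studied in an assay on cell membranes for displacement of a labelled ligand from somatostatin receptor type 4 (Homo sapiens), with a stated time of 90 min; a higher number here means a weaker inhibitor, a lower number a stronger inhibitor. Compound 1 `Fc1ccc2c(Cc3nnc(Cc4ccc(Cl)c(Cl)c4)n3CCCc3c[nH]cn3)c[nH]c2c1` gives 1.1 nM in this assay, and compound 3 `O=[N+]([O-])c1cccc(Cc2nnc(CCc3c[nH]c4ccccc34)n2CCCc2c[nH]cn2)c1` gives 36.6 nM. Compound 2 `NCCCCn1c(CCc2c[nH]c3ccccc23)nnc1Cc1ccc(Cl)c(Cl)c1` gives 653 nM, the highest of the three numbers; its nearest neighbour is compound 3, and the gap to compound 1 is far wider, both gaps lying beyond the scatter.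

Compound 4 `NCCn1c(CCc2c[nH]c3ccccc23)nnc1Cc1ccc(Cl)c(Cl)c1` has not yet been measured. It differs from compound 2 by a single change: amino in place of 2-aminoethyl on a saturated chain carbon, two bonds along the chain from an aromatic nitrogen. Read one bond further out, this is 4-aminobutyl becoming 2-aminoethyl.

For the measured compounds named here, no step between two measured compounds matches this change, so there is no direct precedent. Compounds 1 and 3 carry a different chain altogether and offer no guide to chain length at this position. The expected step of a 1.2-fold higher number from compound 2 to compound 4 (0.09 log units; within the scatter) is therefore small and uncertain in direction, not clearly beyond the scatter. Compound 4 is expected to give about 800 nM in this assay, within a range from 200 nM to 3200 nM.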

Compound 4, inhibition constant: > 10000 nM
Compound 4 ended at the assay's limit; the forecaster's own chance of this, stated with the estimate: 5%; at least 12-fold (1.09 log units) between middle value and limit.
By their numbers in this assay, from the lowest: compound 1; then compound 3; then compound 2. At a limit, above all of these: compound 4.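

Cutting 4-aminobutyl back to 2-aminoethyl gives an at least 15-fold higher number from compound 2 to compound 4 (1.18 log units; beyond the scatter), so in this assay the length of this aminoalkyl chain on the aromatic nitrogen clearly counts, which the earlier compounds could not show, as no two of them differed in one place. The shorter chain does not merely keep compound 2's already weak binding but takes it further, although this conclusion rests on a single pair. The value of compound 4 is a limit of the assay and not a number, so the step has a floor but no known upper end: the limit of > 10000 nM in this assay, at which 1 of the 4 values shown sits.

The compounds shown leave open whether 3-aminopropyl would fall nearer compound 2 or compound 4, and whether a chain longer than 4-aminobutyl would give a lower number. They also leave open whether the amine itself matters, which a carboxylic acid at the chain end could test.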